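The source may hold more compounds than are shown below. What is called first, only, known or untested is meant among the compounds shown, and "the series" means these compounds.

Of the compounds shown here, three built on a shared core have been tested in a functional assay on NCI-H1581 cells (Homo sapiens) for inhibition, read by MTT assay, with a stated time of 48 h, tested at 10 uM; a higher number here means more inhibition at the concentration tested (going by the name of the read-out), a lower number less inhibition. Compound 1 `COc1ccc(F)cc1Nc1cc(NC(=O)Nc2c(Cl)cccc2Cl)ncn1` gives 73.1% there, and compound 3 `COc1cc(Nc2cc(NC(=O)Nc3c(Cl)cccc3Cl)ncn2)cc(OC)c1` gives 68%. Compound 2 `COc1cc(NC(=O)Nc2cc(Nc3ccc(C)c(C)c3)ncn2)cc(OC)c1` stands lowest of the three in this assay with 20.1%; its nearest neighbour is compound 3, whose number lies higher by an amount beyond the usual scatter, and compound 1 lies further away still, also beyond the scatter. Compound 4 `COc1cc(NC(=O)Nc2cc(Nc3ccc(OC)c(I)c3)ncn2)cc(OC)c1` has not yet been measured. It differs from compound 2 in one place: 3-iodo-4-methoxyphenyl in place of 3,4-dimethylphenyl on a nitrogen on an aromatic ring. Among the measured compounds shown here, no pair of measured compounds shares this exact change, so there is no measured step to lean on; compounds 1 and 3 differ from compound 2 elsewhere in the molecule and only show that the read-out can move widely. Against that background a modest upward step is expected, a number 11.9 percentage points higher from compound 2 to compound 4 (beyond the scatter), rather than none beyond the scatter. Compound 4 is accordingly expected to give 32% in this assay, within a range from 10% to 58%.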

Compound 4, a percentage reported as inhibition, at one concentration (the size of the read-out at that concentration, not a potency): 43%
The estimate for compound 4 lay 11 percentage points below the measured number; the range from low to high includes it.
By their numbers in this assay, from the lowest: compound 2; then compound 4; then compounds 3 and 1 (each within the scatter of the next).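

On the aryl group carried by the amino nitrogen, the change from 3,4-dimethylphenyl to 3-iodo-4-methoxyphenyl produces in this assay a number 22.9 percentage points higher from compound 2 to compound 4 (beyond the scatter). Among the compounds shown here, this is the first measured step at this position, and it shows that the read-out responds to this substituent alone, with the rest of the molecule held constant. The compounds shown offer no evidence on why the number rises.

Two groups on the ring change together, so the step cannot be divided between the iodine and the methoxy group; a 3-iodo-4-methylphenyl or a 3-methyl-4-methoxyphenyl group would separate them. On these data alone, it also remains open how other groups at this place, such as a morpholine or a carboxylic acid, would behave, and whether the step carries over when the molecule differs elsewhere.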